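The compounds below may be only part of what the source reports. "The series", "measured", "known", "first", "only" and "open" are said of these compounds alone.

The series rests on a common core carrying an acid-bearing chain on an amide-type nitrogen in a ring, and the compounds are compared in a functional assay on a cell-free system (Platelet, plasma, Homo sapiens) for inhibition; on this read-out higher numbers stand for weaker inhibition and lower numbers for stronger inhibition. Compound 2 `CC(CC(=O)O)N1Cc2ccc(NC(=O)c3ccc4c(c3)CNCC4)cc2C1=O` is the reference point; in this assay compound 2 gives 86 nM. Among the measured compounds shown here, compound 1 `O=C(O)CN1Cc2ccc(NC(=O)c3ccc4c(c3)CNCC4)cc2C1=O` differs from it by carboxymethyl in place of 1-(carboxymethyl)ethyl on an amide-type nitrogen in a ring; in this assay compound 1 gives 120000 nM, and the step of a 1400-fold higher number from compound 2 to compound 1 (3.14 log units; beyond the scatter) is the one counted change whose effect has been measured here.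

Compound 3 `CC(CC(=O)O)N1Cc2ccc(NC(=O)c3ccc(N4CCNCC4)cc3)cc2C1=O` carries the same acid chain as compound 2 on a different core; the difference between the two cores is not broken down here. In this assay compound 3 gives 3740 nM, which places it well away from compound 2 and yet also well away from compound 1.

Compound 4 `O=C(O)CN1Cc2ccc(NC(=O)c3ccc(N4CCNCC4)cc3)cc2C1=O` has not yet been measured. It relates to compound 3 as compound 1 relates to compound 2, by carboxymethyl in place of 1-(carboxymethyl)ethyl on an amide-type nitrogen in a ring, and the place is described in the same words for both pairs, so it is the same change. If the change acts on the core of compound 3 as it did on the core of compound 2, a large step is expected: he expects a 130-fold higher number from compound 3 to compound 4 (2.13 log units; beyond the scatter) for compound 4, because compound 1 showed a 1400-fold higher number from compound 2 to compound 1 (3.14 log units; beyond the scatter). For the measured compounds named here, since only one measured step anchors this, the expected number for compound 4 carries a wide range, 500000 nM between 50000 nM and 3000000 nM, and a real chance that this assay reports only a limit for compound 4.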

Compound 4, half-maximal inhibitory concentration: 3300 nM
Compound 4: middle estimate off by 150-fold (2.18 log units), on the high side; measured number below the stated range.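

In this assay, carboxymethyl in place of 1-(carboxymethyl)ethyl on an amide-type nitrogen in a ring gives a 1.1-fold lower number from compound 3 to compound 4 (0.05 log units; within the scatter), so on this core the two acid chains cannot be told apart. Among the compounds shown here, the same change therefore does not carry the same size of step from one core to the other: the same change on two cores in this assay, a 1400-fold higher number (3.14 log units; beyond the scatter) from compound 2 to compound 1 and a 1.1-fold lower number (0.05 log units; within the scatter) from compound 3 to compound 4, 1600-fold (3.20 log units) apart, beyond the scatter of two such steps With only these two pairs, this shows that the step measured on the core of compound 2 was no guide to the step on the core of compound 3, but it does not show which part of the cores sets the difference, or how the change would read on any third core.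

The compounds shown leave open how a longer chain ending in a carboxylic acid, or a methyl ester in place of that acid, would read on either core. They also leave open whether the large step seen on the core of compound 2 would return on other cores, or whether the near-identical numbers of compound 3 and compound 4 would be the more common result in this series.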